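The source may hold more compounds than are shown below. What is called first, only, known or untested is meant among the compounds shown, and "the series" means these compounds.

Measured in a functional assay on NCI-H322M cells (Homo sapiens) for inhibition, read by sulforhodamine B assay, with a stated time of 48 h; on this read-out lower numbers stand for stronger inhibition of growth and higher numbers for weaker inhibition of growth:
- compound 1 `O=C(Cc1csc2nc(-c3ccc(Br)cc3)cn12)N/N=C/c1ccccc1`: 19100 nM
- compound 2 `O=C(Cc1csc2nc(-c3ccc(Br)cc3)cn12)N/N=C/c1ccc(O)cc1`: 4370 nM
- compound 3 `COc1cccc(OC)c1/C=N/NC(=O)Cc1csc2nc(-c3ccc(Br)cc3)cn12`: 14800 nM

Compound 1 at 19100 nM and compound 3 at 14800 nM lie within the scatter of each other, while compound 2 stands apart at 4370 nM. Compound 1 is thus at the weak end of this small set, though not alone there.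

Compound 4 `O=C(Cc1csc2nc(-c3ccc(Br)cc3)cn12)N/N=C/c1ccc(Cl)cc1Cl` differs from compound 1 as follows: 2,4-dichlorophenyl in place of phenyl on a carbon with a double bond to nitrogen. Two measured steps change the same phenyl: a 4.4-fold lower number from compound 1 to compound 2 (0.64 log units; beyond the scatter) with hydroxy added, and a 1.3-fold lower number from compound 1 to compound 3 (0.11 log units; within the scatter) with 2,6-dimethoxyphenyl entering. Compound 4 carries no hydroxy, and the closer guide is therefore the step to compound 3, which shows no change beyond the scatter. Among the compounds with values here, no chlorine-bearing compound has been measured, so the guidance is thin.

In this assay no step beyond the scatter is expected, with a slight lean toward lower numbers. The expected step is a 1.6-fold lower number from compound 1 to compound 4 (0.20 log units; within the scatter). For compound 4 the estimated value is 12000 nM, with an expected range of 4500 nM to 30000 nM.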

Compound 4, concentration for 50% growth inhibition: 24500 nM
Estimate against measurement, compound 4: 2.0-fold (0.31 log units) below, within the range that was stated.
By their numbers in this assay, from the lowest: compound 2; then compounds 3, 1 and 4 (each within the scatter of the next).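

In this assay, 2,4-dichlorophenyl in place of phenyl on a carbon with a double bond to nitrogen gives no change beyond the scatter (a 1.3-fold higher number from compound 1 to compound 4 (0.11 log units; within the scatter)), and the same holds against 2,6-dimethoxyphenyl (a 1.7-fold higher number from compound 3 to compound 4 (0.22 log units; within the scatter)). Within the data shown here, two differently substituted rings now sit with the unsubstituted phenyl, and compound 2 alone stands apart, with 4-hydroxyphenyl as the only group at this place giving a lower number beyond the scatter (a 5.6-fold higher number from compound 2 to compound 4 (0.75 log units; beyond the scatter)). Nothing available explains this separation.

From the compounds shown here alone, whether compound 2 owes its lower number to the hydroxy itself, or whether other groups at that ring position would do the same, remains open. A 4-methoxyphenyl, a 4-aminophenyl or a 4-carboxyphenyl at this place would bear directly on that question.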